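The source may hold more compounds than are shown below. What is called first, only, known or untested is meant among the compounds shown, and "the series" means these compounds.

Measured so far:
compound 1 `CNc1nc(OC)nc2c1ncn2C1O[C@H](CO)[C@H](O[C@@H]2OC(CO)[C@H](OP(=O)(O)O)C(OP(=O)(O)O)[C@@H]2O)[C@@H]1OP(=O)(O)O` gives 0.17 nM
compound 2 `COc1ncnc2c1ncn2C1O[C@H](CO)[C@H](O[C@@H]2OC(CO)[C@H](OP(=O)(O)O)C(OP(=O)(O)O)[C@@H]2O)[C@@H]1OP(=O)(O)O` gives 0.57 nM

In a functional assay (Hepatocyte) with Rattus norvegicus as the target (on this read-out lower numbers stand for an effect already at smaller amounts and higher numbers for an effect only at larger amounts of compound), compound 2 stands at the highest of the two numbers; the nearest, compound 1, gives a lower number, a gap beyond the scatter. Compound 3 `Nc1ncnc2c1ncn2C1O[C@H](CO)[C@H](O[C@@H]2OC(CO)[C@H](OP(=O)(O)O)C(OP(=O)(O)O)[C@@H]2O)[C@@H]1OP(=O)(O)O` has not been measured. It differs from compound 2 by amino in place of methoxy on an aromatic carbon. Among the measured compounds shown here, no step between measured compounds carries this change, so nothing measured bears on it directly. For compound 3 a modest downward step is expected, a 1.9-fold lower number from compound 2 to compound 3 (0.28 log units; within the scatter), within or just beyond the scatter. Compound 3 is estimated to give 0.3 nM in this assay, with a range from 0.1 nM to 1 nM.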

Compound 3, half-maximal effective concentration: 1 nM
Compound 3: middle estimate off by 3.3-fold (0.52 log units), on the low side; measured number inside the range.
By their numbers in this assay, from the lowest: compound 1; then compounds 2 and 3 (each within the scatter of the next).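

Amino in place of methoxy on this aromatic carbon gives, within this assay, a 1.8-fold higher number from compound 2 to compound 3 (0.24 log units; within the scatter) and so leaves the two groups apart by no more than the scatter. The position therefore accepts this exchange, with its added hydrogen-bond donor, without a step beyond the scatter. Nothing available explains this result.

Open, going by these compounds, is whether a dimethylamino group, an ethoxy group or a chlorine atom on the same carbon would stay at this level. Among the compounds shown here, only one single-place change at this position can be read so far.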